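From Nitrofuran to Plain Phenyl in Ishikawa Cell Inhibition

The source may report more compounds than this note shows. Statements on the series, on what has been measured and on what is new or still open speak of the compounds shown alone.

Of the compounds shown here, two sharing one core have been measured in a functional assay on Ishikawa cells (Homo sapiens) for inhibition, read by MTT assay, with a stated time of 48 h; a lower number here means a stronger inhibitor, a higher number a weaker inhibitor. Compound 1 `CCOC(=O)c1c(N)sc(/N=C/c2ccc([N+](=O)[O-])o2)c1C(=O)OCC` gives 7600 nM, the lowest of the two numbers, so it is the stronger inhibitor of the pair. Compound 2 `CCOC(=O)c1c(N)sc(/N=C/c2ccc(F)cc2)c1C(=O)OCC` gives 32100 nM, a step of a 4.2-fold higher number from compound 1 to compound 2 (0.63 log units; beyond the scatter). Compound 3 `CCOC(=O)c1c(N)sc(/N=C/c2ccccc2)c1C(=O)OCC` has not been measured; it differs from compound 1 as follows: phenyl in place of 5-nitrofuran-2-yl on a carbon with a double bond to nitrogen. Among the measured compounds shown here, the only measured step that bears on this change is the one from compound 1 to compound 2, where a six-membered aromatic ring of carbon only also replaced the 5-nitrofuran-2-yl group and the number rose beyond the scatter; the step to compound 3 leaves out the fluorine as well, so a bare phenyl remains. A step of similar direction and size is therefore expected, a 3.3-fold higher number from compound 1 to compound 3 (0.52 log units; beyond the scatter). Compound 3 is estimated at 25000 nM, with a range from 8000 nM to 80000 nM.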

Compound 3, half-maximal inhibitory concentration: 37900 nM
The estimate for compound 3 lay 1.5-fold (0.18 log units) below the measured number; the range from low to high includes it.
By their numbers in this assay, from the lowest: compound 1; then compounds 2 and 3 (each within the scatter of the next).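

Hydrogen in place of fluoro on an aromatic carbon makes no readable difference in this assay, with a 1.2-fold higher number from compound 2 to compound 3 (0.07 log units; within the scatter). Phenyl in place of 5-nitrofuran-2-yl gives a 5.0-fold higher number from compound 1 to compound 3 (0.70 log units; beyond the scatter), so the rise seen with 4-fluorophenyl does not depend on the fluorine: at this carbon with a double bond to nitrogen, compound 1 stands apart from both compounds with a six-membered ring. Nothing measured here explains why the 5-nitrofuran-2-yl group gives the lower number.

The nitro group and the furan ring change together in these compounds, so a plain furan-2-yl group or a 4-nitrophenyl group would be needed to tell their shares apart. Also open, from the compounds shown here alone, is how an amine or a carboxylic acid on the phenyl ring would read in this assay.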